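The source may hold more compounds than are shown below. What is called first, only, known or untested is meant among the compounds shown, and "the series" means these compounds.

Two closely related natural-product lactones open this study. Compound 1, `C=C1C(=O)O[C@@H]2[C@H]1CCC(C)=C1[C@H]3O[C@](C)([C@H]3O)[C@@H]12`, was tested in a functional assay on KB cells (Homo sapiens) for cytotoxicity (a higher number here means a weaker inhibitor, a lower number a stronger inhibitor), and gives 4.5 ug/mL. Compound 2, `C=C1C(=O)O[C@H]2[C@@H]3[C@@](O)(C(=C)CC[C@@H]12)[C@@H]1C[C@@]3(C)O1`, gives 5.5 ug/mL in this assay, and the two numbers lie within the usual scatter of each other, so compound 1 cannot be placed ahead of or behind compound 2 on these results alone.

The next compound, compound 3, `C=C1C(=O)O[C@@H]2[C@H]1CCC(C)=C1[C@H]3O[C@](C)([C@H]3OC(=O)C(C)CC)[C@@H]12`, has not yet been measured. It differs from compound 1 in a single place: (sec-butyl)carbonyl in place of hydrogen on an oxygen on a saturated carbon. Within the data shown here, no measured pair in this set shows such a change, so there is no direct guide to its effect.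

On the numbers available, the step from compound 1 to compound 3 is expected to be small, a 1.5-fold lower number from compound 1 to compound 3 (0.18 log units; within the scatter), with the direction uncertain. Compound 3 is therefore estimated to give 3 ug/mL in this assay, in a range from 1.2 ug/mL to 8 ug/mL.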

Compound 3, half-maximal inhibitory concentration: 1 ug/mL
The estimate for compound 3 lay 3.0-fold (0.48 log units) above the measured number; measured number outside the range, below it.
By their numbers in this assay, from the lowest: compound 3; then compounds 1 and 2 (each within the scatter of the next).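

In this assay, the change from hydroxy to ((sec-butyl)carbonyl)oxy on this saturated ring carbon gives a 4.5-fold lower number from compound 1 to compound 3 (0.65 log units; beyond the scatter). Among these compounds, this is the first step in the set that lies beyond the usual scatter, and it shows that the hydrogen on this oxygen can be replaced by a (sec-butyl)carbonyl group without losing cytotoxicity, with the number moving towards a stronger inhibitor. Nothing measured here explains why the number falls.

Among the compounds shown here, with only one group tested at this oxygen, it remains open whether the step depends on (sec-butyl)carbonyl itself or would also appear with a smaller acetyl group, a longer acyl chain or a simple methyl group. An acyl group carrying an amine or a carboxylic acid would test the position further.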